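Phenyl for thiophen-2-yl in compound 2

The source may hold more compounds than are shown below. What is called first, only, known or untested is meant among the compounds shown, and "the series" means these compounds.

In a functional assay on T47D cells (Homo sapiens) for cytotoxicity, read by CCK-8 assay and cell counting, with a stated time of 2 days (a higher number here means a weaker inhibitor, a lower number a stronger inhibitor), compound 1 `Oc1ccc(-c2cc(-c3cccs3)nc(-c3ccccc3Cl)c2)cc1` gives 5870 nM, compound 2 `Oc1ccc(-c2cc(-c3cccc(Cl)c3)nc(-c3cccs3)c2)cc1` gives 5350 nM and compound 3 `Oc1cccc(-c2cc(-c3cccc(Cl)c3)nc(-c3cccs3)c2)c1` gives 3410 nM. Compound 2 holds the second highest of the three numbers, and both of its neighbours lie within the scatter: a 1.1-fold lower number from compound 1 to compound 2 (0.04 log units; within the scatter) and a 1.6-fold lower number from compound 2 to compound 3 (0.20 log units; within the scatter). Compound 4 `Oc1ccc(-c2cc(-c3ccccc3)nc(-c3cccc(Cl)c3)c2)cc1` differs from compound 2 in one place: phenyl in place of thiophen-2-yl on an aromatic carbon. Neither measured step touches this ring, and the two steps that were measured are themselves small, so nothing here speaks for a step beyond the scatter in this assay. For compound 4 the expected value is 5000 nM, with a range from 2200 nM to 11000 nM. That estimate means an expected step of a 1.1-fold lower number from compound 2 to compound 4 (0.03 log units; within the scatter), within the scatter.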

Compound 4, half-maximal inhibitory concentration: 4790 nM
Beside the measured number, compound 4's estimate is 1.0-fold (0.02 log units) above it; the range from low to high includes it.
By their numbers in this assay, from the lowest: compounds 3, 4, 2 and 1 (each within the scatter of the next).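

In this assay, among these compounds, the first change at the position next to the ring nitrogen gives a 1.1-fold lower number from compound 2 to compound 4 (0.05 log units; within the scatter), so with phenyl in place of thiophen-2-yl, the ring sulfur is not needed to keep a number of this size. The five-membered and six-membered aromatic rings cannot be told apart here. No measured evidence bears on this result. Only these two aromatic rings are shown at this position, so the effect of an amine, a carboxylic acid or a longer alkyl chain there remains open.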